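The source may hold more compounds than are shown below. What is called first, only, known or untested is meant among the compounds shown, and "the series" means these compounds.

Within the data shown here, compound 2 `Cc1cn(C2CC(N=[N+]=[N-])C(COC(=O)OCCCO)O2)c(=O)[nH]c1=O` is the one member of this small series whose result in an ADME assay for pharmacokinetics (a lower number here means that the compound disappears faster, a higher number that the compound lasts longer), is a plain number: compound 2 gives 0.167 h there. Compound 1 `Cc1cn(C2CC(N=[N+]=[N-])C(COC(=O)OCCO)O2)c(=O)[nH]c1=O` differs from it only in the length of the hydroxyalkyl chain on the carbonate. In this assay compound 1 gives < 0.0167 h, which is a limit of the assay and not a number. Among the measured compounds shown here, the single measured comparison is therefore an at least 10-fold higher number from compound 1 to compound 2 (1.00 log units; beyond the scatter), and because it starts from the limit of < 0.0167 h in this assay, at which 1 of the 2 values shown sits, its true size is known only as a minimum.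

Compound 3 `Cc1cn(C2CC(N=[N+]=[N-])C(COC(=O)OCCCCO)O2)c(=O)[nH]c1=O` lengthens the chain by one more carbon: hydroxymethyl in place of hydroxy on a saturated chain carbon, three bonds along the chain from an oxygen next to a carbonyl group. This is the same kind of change as the measured step, cut one bond further out. Because an at least 10-fold higher number from compound 1 to compound 2 (1.00 log units; beyond the scatter) ran toward a longer half-life, a further lengthening is expected to move in the same direction, but with less certainty, since the earlier step is anchored on the limit of < 0.0167 h in this assay, at which 1 of the 2 values shown sits, rather than on two numbers. The expected step is a 2.4-fold higher number from compound 2 to compound 3 (0.38 log units; beyond the scatter), modest and not guaranteed to clear the scatter. Compound 3 is accordingly estimated at 0.4 h, within a range from 0.15 h to 1.2 h.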

Compound 3, half-life: 0.5 h
For compound 3 the middle estimate is 1.3-fold (0.10 log units) below the measured one; the measured number falls inside the stated range.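

The new result supplies what the earlier pair could not: a step along this chain read between two plain numbers in this assay, namely a 3.0-fold higher number from compound 2 to compound 3 (0.48 log units; beyond the scatter). The rise in half-life with a longer hydroxyalkyl chain on the carbonate therefore no longer rests on a limit alone; it now also appears three bonds along the chain from an oxygen next to a carbonyl group, and none of the three compounds shown goes against it. Taken as one change, 2-hydroxyethyl in place of hydroxy gives an at least 29-fold higher number from compound 1 to compound 3 (1.47 log units; beyond the scatter), and this size is only a minimum because the step starts at a limit of the assay and not a number: the limit of < 0.0167 h in this assay, at which 1 of the 3 values shown sits.

What the compounds shown leave open is whether a still longer chain than 4-hydroxybutyl would continue this rise or whether it would level off or reverse. They also leave open whether the hydroxy at the end of the chain matters for the half-life, as an amine, a carboxylic acid or a plain alkyl end in its place would show.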